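This account rests on a few compounds, and the source may have more. Where it says the series, first, only, none or still open, it means among the compounds named here.

Measured in an ADME assay on a cell-free system (plasma, Rattus norvegicus) for protein binding; on this read-out higher numbers stand for a larger free fraction and lower numbers for a smaller free fraction:
Compound 1 `COc1ccc(F)cc1C1CCN(c2ccn3c(CC(F)(F)F)nnc3c2Cl)CC1`: < 0.01
Compound 2 `COc1cccc(F)c1C1CCN(c2ccn3c(CC4CC4)nnc3c2Cl)CC1`: < 0.01

Both entries are limits of the assay and not numbers, so the limit of < 0.01 in this assay, at which 2 of the 2 values shown sit, is all the data give. Compound 2 stands at < 0.01, which is a limit. Compound 3 `COc1ccc(F)c(F)c1C1CCN(c2ccn3c(CC4CC4)nnc3c2Cl)CC1` differs from compound 2 by fluoro in place of hydrogen on an aromatic carbon, turning 2-fluoro-6-methoxyphenyl into 2,3-difluoro-6-methoxyphenyl. No measured step sizes this change, so no shift beyond the scatter is expected in this assay, in either direction. The expected step that the limit leaves unreadable from compound 2 to compound 3 is small. For compound 3 the estimated value is 0.006, with an expected range of 0.002 to 0.015, and a report as a limit is the likeliest outcome.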

Compound 3, unbound fraction: < 0.01
Compound 3 was reported as a limit; the forecaster's own chance of this, stated with the estimate: 75%; the middle value lies beyond the limit too.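

Compound 2 and compound 3 are both reported only as limits in this assay, so no step can be read between them: the limit of < 0.01 in this assay, at which 3 of the 3 values shown sit.

The compounds shown leave open what the unbound fraction of each actually is, and whether fluoro in place of hydrogen on an aromatic carbon changes it at all.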